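A 4-Chlorophenyl Group in Place of 3-(Methylamino)pyrrolidin-1-yl

The compounds below may be only part of what the source reports. "The series", "measured", "known", "first", "only" and "open" are said of these compounds alone.

Measured compounds:
compound 1 `CNC1CCN(c2ncnc3c2cnn3CCN2CCCCC2)C1`, 25800 nM
compound 2 `c1cn(-c2ncnc3c2cnn3CCN2CCCCC2)cn1`, 13800 nM
compound 3 `Fc1ccc(-c2ncnc3c2cnn3CCN2CCCCC2)cc1`, 95 nM

In an assay on HEK293 cells for displacement of a labelled ligand from Sigma non-opioid intracellular receptor 1 (Homo sapiens), read by scintillation counting, with a stated time of 120 min (on this read-out lower numbers stand for stronger inhibition and higher numbers for weaker inhibition), compound 1 stands at the highest of the three numbers. Compound 2 is nearest to it, with a 1.9-fold lower number from compound 1 to compound 2 (0.27 log units; within the scatter), while compound 3 lies furthest away, with a 270-fold lower number from compound 1 to compound 3 (2.43 log units; beyond the scatter). The step of a 150-fold lower number from compound 2 to compound 3 (2.16 log units; beyond the scatter) points the same way.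

Compound 4 `Clc1ccc(-c2ncnc3c2cnn3CCN2CCCCC2)cc1` has not yet been measured. It differs from compound 1 in one place: 4-chlorophenyl in place of 3-(methylamino)pyrrolidin-1-yl on an aromatic carbon

For the measured compounds named here, the step that bears most directly on this change is the one from compound 1 to compound 3, where a six-membered aromatic ring of carbon only bearing a halogen replaced the same 3-(methylamino)pyrrolidin-1-yl group and the number fell far beyond the scatter. Compound 4 carries the same kind of group, with a chlorine where compound 3 has a fluorine. A large step in the same direction is therefore expected, close in size to a 270-fold lower number from compound 1 to compound 3 (2.43 log units; beyond the scatter), giving a 320-fold lower number from compound 1 to compound 4 (2.51 log units; beyond the scatter). Compound 4 is estimated at 80 nM in this assay, with a range from 25 nM to 250 nM.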

Compound 4, inhibition constant: 43 nM
The estimate for compound 4 lay 1.9-fold (0.27 log units) above the measured number; the range from low to high includes it.
By their numbers in this assay, from the lowest: compound 4; then compound 3; then compounds 2 and 1 (each within the scatter of the next).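

In this assay chloro in place of fluoro on the aromatic ring is a modest step, but one beyond the scatter (a 2.2-fold lower number from compound 3 to compound 4 (0.34 log units; beyond the scatter)). The large drop seen with 4-fluorophenyl at this aromatic carbon is therefore not unique to that group, since 4-chlorophenyl also gives it, both against 3-(methylamino)pyrrolidin-1-yl (a 600-fold lower number from compound 1 to compound 4 (2.78 log units; beyond the scatter)) and against 1H-imidazol-1-yl (a 320-fold lower number from compound 2 to compound 4 (2.51 log units; beyond the scatter)). Nothing available explains why the chlorine-bearing ring gives the lowest number of the four.

The compounds shown leave open whether a 4-bromophenyl group would continue the step from fluoro to chloro. They also leave open what an unsubstituted phenyl or a 4-methoxyphenyl group would give at this position.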